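This account rests on a few compounds, and the source may have more. Where it says the series, first, only, none or still open, it means among the compounds named here.

Measured so far in a functional assay on A549 cells (Homo sapiens) for cytotoxicity, read by MTT assay, with a stated time of 72 h; on this read-out higher numbers stand for an effect only at larger amounts of compound and lower numbers for an effect already at smaller amounts:
- compound 1 `O=c1cc(NC2CC2)cc(-c2ccccc2)o1`: > 30 uM (a limit)
- compound 2 `COc1ccc(Nc2cc(C3CCCCC3)oc(=O)c2)cc1`: 4.62 uM
- compound 3 `CCCCCc1cc(Nc2ccc(OC)cc2)cc(=O)o1`: 4.42 uM

Compound 1 gives no number, and stands at the limit of > 30 uM in this assay, at which 1 of the 3 values shown sits. Compound 4 `Cc1ccc(Nc2cc(-c3ccccc3)oc(=O)c2)cc1` keeps the core of compound 1 and changes one group: 4-methylphenyl in place of cyclopropyl on a nitrogen on an aromatic ring.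

Within the data shown here, no measured step covers this change directly. The only one, a 1.0-fold lower number from compound 2 to compound 3 (0.02 log units; within the scatter), lies within the scatter and concerns an aromatic carbon, not the nitrogen. The indirect evidence is that compound 2 and compound 3 both carry a six-membered aromatic ring on that nitrogen, and both give numbers in this assay. They also differ from compound 1 elsewhere, so the comparison is loose, and neither shares the phenyl group of compound 4.

A move towards lower numbers is therefore expected in this assay, with its size poorly defined. The expected change is an at least 3.7-fold lower number from compound 1 to compound 4 (0.57 log units; beyond the scatter). Compound 4 is estimated at 8 uM, with an expected range of 3 uM to 25 uM.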

Compound 4, concentration for half-maximal effect: 0.067 uM
Estimate against measurement, compound 4: 120-fold (2.08 log units) above; measured number below the stated range.
By their numbers in this assay, from the lowest: compound 4; then compounds 3 and 2 (each within the scatter of the next). At a limit, above all of these: compound 1.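

In this assay, 4-methylphenyl in place of cyclopropyl on the nitrogen gives an at least 440-fold lower number from compound 1 to compound 4 (2.65 log units; beyond the scatter). Among these compounds, this is the first step read at this nitrogen, and it shows that the group there can change the read-out far beyond the scatter, whereas the only earlier step concerned an aromatic carbon and stayed within it. Compound 1 stands at > 30 uM, a limit and not a number, so the step gives only a lower bound on the change: the limit of > 30 uM in this assay, at which 1 of the 4 values shown sits.

Open, from the compounds shown here alone, is whether the change needs the methyl group or follows from a six-membered aromatic ring on that nitrogen alone, as an unsubstituted phenyl there would show. Also open, going by these compounds, is how a carboxylic acid or an amine on that ring, or a saturated cyclohexyl ring on the nitrogen, would read on the core of compound 4.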